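A few compounds are considered here, and "the series" means these few. Any claim that something is new, unique, unknown or untested is made for them only; others in the source may bear on it.

Measured compounds in a functional assay on cells (Panel NCI-60 (60 carcinoma cell lines), Homo sapiens) for inhibition, read by colorimetric assay, with a stated time of 3 days; on this read-out higher numbers stand for weaker inhibition of growth and lower numbers for stronger inhibition of growth:
compound 1, `O=C(CCCCCCNC(=O)C(O)(O)C(F)(F)F)Nc1nc2ccccc2s1`: 3390 nM
compound 2, `COc1ccc2sc(NC(=O)CCCCCCNC(=O)C(O)(O)C(F)(F)F)nc2c1`: 1230 nM
compound 3, `O=C(CCCCCCNC(=O)C(O)(O)C(F)(F)F)Nc1ncc(-c2ccccc2)s1`: 3020 nM

Compound 3 gives the second highest of the three numbers. Its value and that of compound 1 lie within the scatter of each other, so no order between these two can be read. Compound 2 gives a lower number than compound 3, and that gap lies beyond the scatter.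

Compound 4, `COc1ccc(-c2cnc(NC(=O)CCCCCCNC(=O)C(O)(O)C(F)(F)F)s2)cc1`, is not yet measured. Relative to compound 3 the change is methoxy in place of hydrogen on an aromatic carbon.

Within the data shown here, the one measured step of the same kind is a 2.8-fold lower number from compound 1 to compound 2 (0.44 log units; beyond the scatter), where the methoxy enters on the shared core rather than on the phenyl. Among the measured compounds shown here, no measured step touches the phenyl of compound 3 itself, so how far that step carries over to compound 4 is uncertain. For the measured compounds named here, it is nonetheless the only guide available, and it points towards a lower number. The step expected for compound 4 is therefore a 1.5-fold lower number from compound 3 to compound 4 (0.18 log units; within the scatter), set smaller than the measured step, with a real chance that it ends within the scatter. For compound 4 the estimate in this assay is 2000 nM, with a range from 900 nM to 4500 nM.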

Compound 4, concentration for 50% growth inhibition: 1000 nM
The estimate for compound 4 lay 2.0-fold (0.30 log units) above the measured number; low and high end bracket the measured number.
By their numbers in this assay, from the lowest: compounds 4 and 2 (each within the scatter of the next); then compounds 3 and 1 (each within the scatter of the next).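

In this assay, among these compounds, the change from phenyl to 4-methoxyphenyl gives a 3.0-fold lower number from compound 3 to compound 4 (0.48 log units; beyond the scatter), which shows that the phenyl itself responds to methoxy, something the earlier compounds could not show. The methoxy step now stands on two cores, and its size barely differs between them: the same change on two cores in this assay, a 2.8-fold lower number (0.44 log units; beyond the scatter) from compound 1 to compound 2 and a 3.0-fold lower number (0.48 log units; beyond the scatter) from compound 3 to compound 4, 1.1-fold (0.04 log units) apart, within the scatter of two such steps. The agreement rests on these two pairs alone, neither of which goes against it, and the methoxy enters at a different place in each, on the phenyl in one and on the shared core in the other.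

On these data alone, it remains open whether the lower number belongs to methoxy specifically or would also follow from another group at this carbon, a question that a hydroxyl, a fluorine or a dimethylamino group at the same place would address. Also open, as far as these compounds go, is how much the chain contributes to these numbers, which a longer chain or a shorter chain on either core would help to settle.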